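The source may report more compounds than this note shows. Statements on the series, on what has been measured and on what is new or still open speak of the compounds shown alone.

Measured compounds:
compound 1, `NC1=NC2(CCOCC2)N(OCCCOc2ccc(Cl)c(Cl)c2)C(N)=N1`: > 90%
compound 2, `NC1=NC2(CCOCC2)N(OCCCOc2cccc(Cl)c2Cl)C(N)=N1`: 81.7%
compound 3, `NC1=NC2(CCOCC2)N(OCCCOc2ccccc2Cl)C(N)=N1`: 83.3%

In an assay on isolated protein for inhibition of Dihydrofolate reductase (Homo sapiens), read by spectrophotometry, using NADPH, with stated times of 5 s and 6 min, tested at 5 uM (a higher number here means a stronger effect of the compound at the concentration tested, a lower number a weaker effect), compound 1 reaches > 90%, which is a limit of the assay rather than a number (the limit of > 90% in this assay, at which 1 of the 3 values shown sits). Compound 2 gives 81.7% and compound 3 gives 83.3%. Compound 3 stands level with compound 2, since a number 1.6 percentage points higher from compound 2 to compound 3 (within the scatter). Compound 4, `COc1ccc(OCCCON2C(N)=NC(N)=NC23CCOCC3)cc1`, differs from compound 3 as follows: 4-methoxyphenyl in place of 2-chlorophenyl on an oxygen on a saturated carbon. The steps on this same oxygen, a number at least 8.3 percentage points lower from compound 1 to compound 2 (that floor lies within the scatter) and a number at least 6.7 percentage points lower from compound 1 to compound 3 (that floor lies within the scatter), both start from a limit, and a number 1.6 percentage points higher from compound 2 to compound 3 (within the scatter) shows that exchanging a chloro on the ring hardly moves the read-out. No step beyond the scatter is therefore expected, and compound 4 is estimated at 80%, between 62% and 92%, which means an expected a number 3.3 percentage points lower from compound 3 to compound 4 (within the scatter).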

Compound 4, a percentage reported as inhibition, at one concentration (the size of the read-out at that concentration, not a potency): > 90%
Compound 4: a limit, no number; the forecaster's own chance of this, stated with the estimate: 15%; middle value at least 10 percentage points away from the limit.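

In this assay compound 4 gives > 90%, which is a limit of the assay and not a number: the limit of > 90% in this assay, at which 2 of the 4 values shown sit.

The ring on this oxygen therefore needs no chloro to reach that limit: compound 4 carries 4-methoxyphenyl, with a number at least 6.7 percentage points higher from compound 3 to compound 4 (that floor lies within the scatter) and a number at least 8.3 percentage points higher from compound 2 to compound 4 (that floor lies within the scatter). The step between compound 1 and compound 4 cannot be read, as both values are limits.

A read-out at one concentration leaves the order of these two compounds open. Also open, as far as these compounds go, is whether an amine in place of the methoxy group, or a longer chain on the oxygen, would hold this read-out.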